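Swapping a butyl chain for a hydroxylated ring on the amine

The source may hold more compounds than are shown below. What is called first, only, known or untested is meant among the compounds shown, and "the series" means these compounds.

Three compounds share one core and differ only in the group on the ring nitrogen. Compound 1 `OCCNc1nc(-c2ccccc2)nc2c1nnn2Cc1ccccc1` gives 38000000 nM in an assay on isolated protein for binding affinity to adenosine receptor A1 (Bos taurus); on this read-out higher numbers stand for weaker inhibition and lower numbers for stronger inhibition. Compound 2 `OCCCNc1nc(-c2ccccc2)nc2c1nnn2Cc1ccccc1` gives 21400000 nM, and compound 3 `CCCCNc1nc(-c2ccccc2)nc2c1nnn2Cc1ccccc1` gives 11000000 nM. Compound 3 has the lowest of the three numbers: the step of a 3.5-fold lower number from compound 1 to compound 3 (0.54 log units; beyond the scatter) is beyond the scatter, while a 1.9-fold lower number from compound 2 to compound 3 (0.29 log units; within the scatter) and a 1.8-fold lower number from compound 1 to compound 2 (0.25 log units; within the scatter) are not.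

Compound 4 `OC1CCC(Nc2nc(-c3ccccc3)nc3c2nnn3Cc2ccccc2)CC1` has not yet been measured. It differs from compound 3 in one place: 4-hydroxycyclohexyl in place of butyl on a nitrogen on an aromatic ring. The change brings back a hydroxy group of the kind carried by compound 1 and compound 2, and at the same time enlarges the carbon part. Among the measured compounds shown here, the steps that bear on it, a 3.5-fold lower number from compound 1 to compound 3 (0.54 log units; beyond the scatter) and a 1.9-fold lower number from compound 2 to compound 3 (0.29 log units; within the scatter), were small or within the scatter, so no step beyond the scatter is expected in either direction. The account therefore expects compound 4 to give about 10000000 nM in this assay, between 3000000 nM and 35000000 nM, which would mean a step of a 1.1-fold lower number from compound 3 to compound 4 (0.04 log units; within the scatter).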

Compound 4, inhibition constant: 2700000 nM
The estimate for compound 4 lay 3.7-fold (0.57 log units) above the measured number, and the stated range ends above it.
By their numbers in this assay, from the lowest: compound 4; then compounds 3, 2 and 1 (each within the scatter of the next, the first and the last beyond it).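

In this assay, a hydroxy group is no obstacle to a lower number at this position on a nitrogen on an aromatic ring, provided it is carried on a six-membered carbon ring: the change shows a 4.1-fold lower number from compound 3 to compound 4 (0.61 log units; beyond the scatter) even though compound 3 has no hydroxy group. Compared with the open hydroxylated chains, the 4-hydroxycyclohexyl group gives a 7.9-fold lower number from compound 2 to compound 4 (0.90 log units; beyond the scatter) and a 14-fold lower number from compound 1 to compound 4 (1.15 log units; beyond the scatter) as the steps, so the chain-bearing compounds with a hydroxy group all stand beyond the scatter of compound 4. Nothing among the data shown accounts for these steps.

On these data alone, whether the ring or its hydroxy group carries the step remains open. A plain cyclohexyl group, or an amine or methoxy group in place of the hydroxy group on the ring, would separate the two.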